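Swapping the ether group on the shared core

A few compounds are considered here, and "the series" means these few. Any claim that something is new, unique, unknown or untested is made for them only; others in the source may bear on it.

This series shares one core, varied only in the group attached to the oxygen on an aromatic ring. Compound 1 `CCCCCOc1cc(CCc2nc(C)c(CC)s2)nc(NCc2cc(Cl)cc(NC(=O)OC(C)C)c2)c1` carries a pentyloxy chain there; in an assay on cells for binding affinity to Neuropeptide Y receptor type 1 (Homo sapiens) (a higher number here means a weaker inhibitor, a lower number a stronger inhibitor), compound 1 gives 35 nM. Compound 2 `CCc1sc(CCc2cc(OCC3(C)CC3)cc(NCc3cc(Cl)cc(NC(=O)OC(C)C)c3)n2)nc1C` instead carries a (1-methylcyclopropyl)methoxy group, and in this assay compound 2 gives 17 nM. For the measured compounds named here, the one measured step, a 2.1-fold lower number from compound 1 to compound 2 (0.31 log units; beyond the scatter), is modest but beyond the scatter, so compound 2 stands as the lower of the two numbers.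

Compound 3 `CCc1sc(CCc2cc(OC3CCOCC3)cc(NCc3cc(Cl)cc(NC(=O)OC(C)C)c3)n2)nc1C` changes the same position again: oxan-4-yl in place of (1-methylcyclopropyl)methyl on an oxygen on an aromatic ring. The step from compound 1 to compound 2 shows that this position tolerates a reshaped carbon group with little change in the number. Nothing measured speaks to a ring oxygen at this place, so the direction is uncertain; the expected outcome is a step of roughly the size seen so far, and a 1.8-fold higher number from compound 2 to compound 3 (0.25 log units; within the scatter) is estimated here as a mild rise. In this assay compound 3 is expected to give about 30 nM, with a plausible range from 10 nM to 90 nM.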

Compound 3, half-maximal inhibitory concentration: 4.4 nM
The estimate for compound 3 lay 6.8-fold (0.83 log units) above the measured number; measured number outside the range, below it.
By their numbers in this assay, from the lowest: compound 3; then compound 2; then compound 1.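

The earlier compounds shown here carried only carbon groups on this oxygen, so they said nothing about a ring holding a hetero atom. Oxan-4-yl, with its one ring oxygen and one hydrogen-bond acceptor, is not merely tolerated here: in this assay it gives a 3.9-fold lower number from compound 2 to compound 3 (0.59 log units; beyond the scatter), and against the open chain of compound 1 it gives an 8.0-fold lower number from compound 1 to compound 3 (0.90 log units; beyond the scatter), so compound 3 has the lowest number of the three. No supporting measurement is available to explain why the number falls with this change.

The change from (1-methylcyclopropyl)methoxy to (oxan-4-yl)oxy alters several things at once, including the ring size, the presence of a ring oxygen and the way the ring is joined to the oxygen on the aromatic ring, and the compounds shown do not separate these. A cyclohexyl group on the same oxygen would test the ring without its oxygen, while a piperidin-4-yl group, with a ring amine in place of the ring oxygen, would show whether another hetero atom at that ring position gives a similar number.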